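A methyl gives way to trifluoromethyl

The compounds below may be only part of what the source reports. "The series", "measured", "known", "first", "only" and "open" are said of these compounds alone.

Readings in a physicochemical assay for solubility, in phosphate buffer (on this read-out higher numbers stand for higher solubility and lower numbers for lower solubility), for the measured compounds:
Compound 1 `Cc1cc(N[C@H](CCCCN)C(=O)NO)cc(C)c1F` reads > 5 ug/mL as a limit
Compound 2 `Cc1cc(N[C@H](CCCCNCc2ccccc2F)C(=O)NO)cc(C)c1F` reads > 5 ug/mL as a limit
Compound 3 `Cc1ccc(CNCCCC[C@@H](Nc2cc(C)c(F)c(C)c2)C(=O)NO)cc1` reads > 5 ug/mL as a limit

Compound 3 stands at > 5 ug/mL in this assay as a limit of the assay and not a number. Going by the values given here, the series so far gives the limit of > 5 ug/mL in this assay, at which 3 of the 3 values shown sit, and nothing firmer.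

Compound 4 `Cc1cc(N[C@H](CCCCNCc2ccc(C(F)(F)F)cc2)C(=O)NO)cc(C)c1F` carries trifluoromethyl in place of methyl on an aromatic carbon, para to a large group. The change is trifluoromethyl in place of methyl on an aromatic carbon and it turns 4-methylphenyl to 4-(trifluoromethyl)phenyl.

The closest measured change is a step that the two limits leave unreadable from compound 2 to compound 3 on the same benzyl position. The other two are a step that the two limits leave unreadable from compound 1 to compound 2 and a step that the two limits leave unreadable from compound 1 to compound 3 on the amine nitrogen. None of these has a readable size or direction, so no step beyond the scatter is expected in this assay for this change. The step expected is a step that the limit leaves unreadable from compound 3 to compound 4 on this reading. The value estimated for compound 4 is 8 ug/mL with an expected range from 4 ug/mL to 30 ug/mL and a good chance of a limit in place of a number.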

Compound 4, solubility: > 5 ug/mL
Compound 4 ended at the assay's limit; the forecaster's own chance of this, stated with the estimate: 65%; the middle value does not contradict the limit.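

In this assay compound 4 gives > 5 ug/mL, a limit of the assay and not a number, so its steps from compound 2 and compound 3 cannot be read. The compounds shown leave open what number any of them would reach, and whether trifluoromethyl in place of methyl shifts it, since all that is available is this: the limit of > 5 ug/mL in this assay, at which 4 of the 4 values shown sit.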